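Aziridinyl quinone series: alkyl side chains at the ring carbon

The source may hold more compounds than are shown below. What is called first, only, known or untested is meant among the compounds shown, and "the series" means these compounds.

Compounds measured in a functional assay on L1210 cells (Mus musculus), with a stated time of 1 days; a lower number here means a less potent compound, a higher number a more potent compound, by a factor of ten per unit of this negative logarithm:
compound 1 `CCCC1=C(N2CC2)C(=O)C(CCC)=C(N2CC2)C1=O` gives 4.32
compound 2 `CC1=C(N2CC2)C(=O)C(CCC(=O)N(C)C)=C(N2CC2)C1=O` gives 5.09
compound 3 `CC1=C(N2CC2)C(=O)C(COc2ccccc2)=C(N2CC2)C1=O` gives 4.68

Compound 2 stands highest of the three; compound 3 follows, and compound 1 lies furthest below. The change from compound 2 to compound 4 `CC1=C(N2CC2)C(=O)C(C(C)C)=C(N2CC2)C1=O` is isopropyl in place of 2-(dimethylcarbamoyl)ethyl on a double-bonded ring carbon. Within the data shown here, the only single-point step recorded, a number 0.41 log units lower from compound 2 to compound 3 (beyond the scatter), shows that exchanging the (dimethylcarbamoyl)methyl group costs a modest amount. Compound 1, which carries plain propyl chains and no amide, sits well below compound 2, so a small alkyl group in place of the amide-bearing chain is expected to lower the result further. For compound 4 the expected step is a number 0.59 log units lower from compound 2 to compound 4 (beyond the scatter), with an estimated value of 4.5 (range 4 to 5).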

Compound 4, logarithm of the reciprocal of the active concentration, log(1/C): 4.96
Compound 4: middle estimate off by 0.46 log units, on the low side; the measured number falls inside the stated range.
By their numbers in this assay, from the lowest: compound 1; then compounds 3, 4 and 2 (each within the scatter of the next, the first and the last beyond it).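

At this double-bonded ring carbon, exchanging 2-(dimethylcarbamoyl)ethyl for isopropyl in this assay gives a number 0.13 log units lower from compound 2 to compound 4 (within the scatter), so the amide chain is not required for a number at the level of compound 2. Not every exchange behaves this way: a number 0.41 log units lower from compound 2 to compound 3 (beyond the scatter). Nothing available bears on the reason for this difference.

Open, on these data alone, is whether a carboxylic acid or a primary amine at the end of the chain on this ring carbon would match isopropyl, with the methyl and both aziridin-1-yl groups kept.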